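Pyridin-4-yl for a chlorinated phenyl on the pyrazole core

This account rests on a few compounds, and the source may have more. Where it says the series, first, only, none or still open, it means among the compounds named here.

Three compounds sharing a substituted thiazolyl-pyrazole core have been examined in a functional assay on BJAB cells (Homo sapiens) for antiproliferative activity, with a stated time of 4 days; a higher number here means that more compound is needed for the effect, a lower number that less compound is needed. Compound 2 `Cc1cc(Cl)cc(-c2c(C)nn(-c3nc(-c4ccc(Cl)c(Cl)c4)c(SC(C)C)s3)c2C(=O)O)c1` gives 663 nM. Compound 3 `COC(=O)c1c(Cc2ccccc2[N+](=O)[O-])c(C)nn1-c1nc(-c2ccc(Cl)c(Cl)c2)c(SC(C)C)s1`, which carries a methyl ester and a nitrobenzyl group on the core, gives 93000 nM. Compound 1 `Cc1c(-c2cc(Cl)cc(Cl)c2)c(C(=O)O)nn1-c1nc(-c2cccnc2)c(SC(C)C)s1` is reported as "not active" (no number reported) without any number. Among the two compounds with a number, compound 2 stands lowest; compound 3 lies far above it, and that gap is well beyond the usual scatter.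

Compound 4 `Cc1nn(-c2nc(-c3ccc(Cl)c(Cl)c3)c(SC(C)C)s2)c(C(=O)O)c1-c1ccncc1` has not yet been measured. It differs from compound 2 in a single place: pyridin-4-yl in place of 3-chloro-5-methylphenyl on an aromatic carbon.

For the measured compounds named here, no measured pair in this set isolates this particular change, so its size cannot be read off from the data. Compound 2 is the only point of reference, and the other two compounds differ from it in several places at once. Going by the values given here, the author expects that the step of a 7.5-fold higher number from compound 2 to compound 4 (0.88 log units; beyond the scatter) will go upward in this assay, beyond the scatter, since a distinct aromatic ring replaces the one present in compound 2. Compound 4 is therefore estimated at 5000 nM in this assay, with a range from 1000 nM to 30000 nM.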

Compound 4, half-maximal effective concentration: 5900 nM
Estimate against measurement, compound 4: 1.2-fold (0.07 log units) below, within the range that was stated.
By their numbers in this assay, from the lowest: compound 2; then compound 4; then compound 3.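

For the compounds shown here, the exchange of 3-chloro-5-methylphenyl for pyridin-4-yl gives the first reading of this position in this assay, with an 8.9-fold higher number from compound 2 to compound 4 (0.95 log units; beyond the scatter) marking a clear loss on an aromatic carbon next to the ring atom that bears a carboxy group. The earlier compounds shown here could not show this, as compound 1 and compound 3 each differ from compound 2 in several places, while this pair isolates the aromatic ring at this one position and shows that the number depends on which ring sits there. Compound 4 still gives a number, 5900 nM, so this replacement raises the number without abolishing the read-out, though nothing available explains the size of the step.

The step combines several changes, since the chlorine and the methyl group leave while a ring nitrogen, counted as one hydrogen-bond acceptor, enters, and this single pair cannot separate their contributions. An unsubstituted phenyl ring, or a pyridin-4-yl ring carrying a chlorine or a methyl group, would be needed to tell which of these changes accounts for the step.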